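Removing the Aryl Group from a Piperazine Chain

The compounds below may be only part of what the source reports. "The series", "measured", "known", "first", "only" and "open" are said of these compounds alone.

The three compounds share a chromanol core. Compound 1, `Cc1c(C)c2c(c(C)c1O)CCC(C)(C(=O)NCc1cccnc1)O2`, carries an amide; in a functional assay (brain) for inhibition, with Rattus norvegicus as the target (a higher number here means a weaker inhibitor, a lower number a stronger inhibitor), compound 1 gives 47000 nM. Compound 2, `COc1ccccc1N1CCN(CC2(C)CCc3c(C)c(O)c(C)c(C)c3O2)CC1`, gives 1000 nM, and compound 3, `Cc1c(C)c2c(c(C)c1O)CCC(C)(CN1CCN(c3ncccn3)CC1)O2`, gives 1000 nM. Compound 3 thus stands level with compound 2, the two together at the lowest numbers seen, while compound 1 sits far higher. The one step among these, no change at the digits printed from compound 2 to compound 3 (within the scatter), shows that exchanging one aromatic ring for another on the ring nitrogen left the number unchanged.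

Compound 4, `Cc1c(C)c2c(c(C)c1O)CCC(C)(CN1CCNCC1)O2`, differs from compound 3 in this way: hydrogen in place of pyrimidin-2-yl on an amine nitrogen in a ring. For the measured compounds named here, no measured step covers the loss of the whole aromatic ring, so the step of no change at the digits printed from compound 2 to compound 3 (within the scatter) bears only loosely on it. The expected change is a modest rise in this assay, estimated as a 4.0-fold higher number from compound 3 to compound 4 (0.60 log units; beyond the scatter), because the aromatic ring on the ring nitrogen is the only feature shared by the two low values that compound 2 gives at 1000 nM and compound 3 gives at 1000 nM. Compound 4 is therefore estimated at 4000 nM, within a range of 1000 nM to 25000 nM.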

Compound 4, half-maximal inhibitory concentration: 1000 nM
Estimate against measurement, compound 4: 4.0-fold (0.60 log units) above, and the stated range covers the measured number.
By their numbers in this assay, from the lowest: compounds 2, 3 and 4 (each within the scatter of the next); then compound 1.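

Removing the pyrimidin-2-yl from the ring nitrogen gives no change at the digits printed from compound 3 to compound 4 (within the scatter) in this assay and removing the 2-methoxyphenyl gives no change at the digits printed from compound 2 to compound 4 (within the scatter) in the same assay. For the compounds shown here, until now, the only step at this position swapped one aromatic ring for another, so it could not show whether having an aromatic ring there mattered; these steps show that the number holds with only a hydrogen on that nitrogen. Nothing available explains why the number stays level.

The compounds shown leave open whether a methyl, an acetyl or a benzyl group on this nitrogen would keep the number at the same level. They also leave open whether the ring with its two nitrogens matters, since no open-chain amine such as dimethylamino stands in its place.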